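Removing the Benzoyl Group from Compound 2

The compounds below may be only part of what the source reports. "The series", "measured", "known", "first", "only" and "open" are said of these compounds alone.

compound 1, `Cc1ccc(/C=N/N(C(=O)c2ccccc2)C(=O)c2ccncc2)cc1`: 100 ug/mL in an ADME assay on HeLa cells (Homo sapiens) for cytotoxicity; on this read-out higher numbers stand for lower toxicity in this test and lower numbers for higher toxicity in this test
compound 2, `CSc1ccc(/C=N/N(C(=O)c2ccccc2)C(=O)c2ccncc2)cc1`: > 100 ug/mL in this assay, which is a limit of the assay and not a number

Compound 2 therefore stands only at a limit in this assay. Among the measured compounds shown here, the one measured step, a number no lower from compound 1 to compound 2 (the limit leaves the size open), has no readable size because of the limit of > 100 ug/mL in this assay, at which 1 of the 2 values shown sits. Compound 3, `CSc1ccc(/C=N/NC(=O)c2ccncc2)cc1`, differs from compound 2 by hydrogen in place of benzoyl on an amide-type nitrogen. For the measured compounds named here, no measured step involves this change, so the expectation rests on the limit of compound 2 alone. Compound 3 is expected at 100 ug/mL, within 50 ug/mL to 200 ug/mL. This estimate means an expected step of a number no higher from compound 2 to compound 3 (the limit leaves the size open), none beyond the scatter.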

Compound 3, minimum cytotoxic concentration: 100 ug/mL
Beside the measured number, compound 3's estimate shows no gap at the digits printed, within the range that was stated.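

With hydrogen in place of benzoyl on the amide-type nitrogen, compound 3 gives 100 ug/mL in this assay, so this position also returns a number without the benzoyl group. The change reads as a number no higher from compound 2 to compound 3 (the limit leaves the size open). Compound 2 stands at a limit and not a number, so the size of this change cannot be read: the limit of > 100 ug/mL in this assay, at which 1 of the 3 values shown sits.

The compounds shown leave open how an acetyl group or a longer alkyl chain on this nitrogen would read in this assay. They also leave open whether an amine in place of methylsulfanyl would alter the reading of compound 3.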